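One more methoxy on the aromatic ring of compound 3

The compounds below may be only part of what the source reports. "The series", "measured", "known", "first", "only" and "open" are said of these compounds alone.

In a functional assay on A549 cells (Homo sapiens) for inhibition, read by MTT assay, with a stated time of 48 h (a lower number here means a stronger inhibitor of growth, a higher number a weaker inhibitor of growth), compound 1 `Cn1cc(C2CC(c3ccc(F)cc3)=NN2C(=O)c2cccnc2)c2cc(Br)ccc21` gives 1380 nM and compound 2 `COc1ccc(C2=NN(C(=O)c3cccnc3)C(c3cn(C)c4ccc(Br)cc34)C2)cc1` gives 1190 nM while compound 3 `COc1ccc(C2=NN(C(=O)c3cccnc3)C(c3cn(C)c4ccc(Br)cc34)C2)cc1OC` gives 2380 nM and stands within the scatter of both others. The change methoxy in place of hydrogen on an aromatic carbon leads to compound 4 `COc1cc(C2=NN(C(=O)c3cccnc3)C(c3cn(C)c4ccc(Br)cc34)C2)cc(OC)c1OC` by methoxy in place of hydrogen on an aromatic carbon, turning 3,4-dimethoxyphenyl into 3,4,5-trimethoxyphenyl. The closest measured precedent, the same kind of change, is a 2.0-fold higher number from compound 2 to compound 3 (0.30 log units; within the scatter) and lies within the scatter. The steps of a 1.2-fold lower number from compound 1 to compound 2 (0.06 log units; within the scatter) and a 1.7-fold higher number from compound 1 to compound 3 (0.24 log units; within the scatter) also stay within the scatter. No step beyond the scatter is expected in this assay here. The expected step is a 1.1-fold lower number from compound 3 to compound 4 (0.03 log units; within the scatter) and remains within the scatter. Compound 4 is expected at 2200 nM and estimated to fall from 800 nM up to 5500 nM when measured.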

Compound 4, concentration for 50% growth inhibition: > 10000 nM
Compound 4: only a limit was reported; the forecaster's own chance of this, stated with the estimate: 3%; middle value at least 4.5-fold (0.65 log units) from the limit.
By their numbers in this assay, from the lowest: compounds 2, 1 and 3 (each within the scatter of the next). At a limit, above all of these: compound 4.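

In this assay compound 4 is reported only as a limit: the limit of > 10000 nM in this assay, at which 1 of the 4 values shown sits. Methoxy in place of hydrogen on the aromatic carbon ortho to a methoxy group gives an at least 4.2-fold higher number from compound 3 to compound 4 (0.62 log units; beyond the scatter), whereas the same kind of change elsewhere on the ring gave a 2.0-fold higher number from compound 2 to compound 3 (0.30 log units; within the scatter), so this position is the first where the change shows a step beyond the scatter. The 3,4,5-trimethoxyphenyl group also stands apart from the other two aryl groups, with an at least 8.4-fold higher number from compound 2 to compound 4 (0.92 log units; beyond the scatter) and an at least 7.2-fold higher number from compound 1 to compound 4 (0.86 log units; beyond the scatter), although the three earlier compounds stayed within the scatter of one another.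

From the compounds shown here alone, how far compound 4 lies past its limit remains open. So does whether a hydroxy group, an amine or a chlorine at this position would give the same result as methoxy.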